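Removing One Chloro Group From Compound 3

The source may hold more compounds than are shown below. What is called first, only, known or untested is meant among the compounds shown, and "the series" means these compounds.

Within the data shown here, in an ADME assay on J774.A1 cells (Mus musculus) for cytotoxicity, read by MTT assay, with a stated time of 72 h (a lower number here means that less compound is tolerated, a higher number that more compound is tolerated), compound 3 `COC(=O)C1=C(C)N(c2ccc(Cl)c(Cl)c2)C(C)=C(C(=O)OC)C1[C@@H]1O[C@H]2OC(C)(C)O[C@H]2[C@@H]1O` gives 29.9 ug/mL, the highest of the three numbers measured so far. Compound 2 `COC(=O)C1=C(C)N(c2ccc(C)cc2)C(C)=C(C(=O)OC)C1[C@@H]1O[C@H]2OC(C)(C)O[C@H]2[C@@H]1OCc1ccccc1` stands at 7.66 ug/mL and compound 1 `COC(=O)C1=C(C)N(c2ccc(Cl)cc2)C(C)=C(C(=O)OC)C1[C@@H]1O[C@H]2OC(C)(C)O[C@H]2[C@@H]1OCc1ccccc1` at 4.22 ug/mL. Compound 3 is therefore the best tolerated of the three, although the other two differ from it in more than one place.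

The next compound, compound 4 `COC(=O)C1=C(C)N(c2ccc(Cl)cc2)C(C)=C(C(=O)OC)C1[C@@H]1O[C@H]2OC(C)(C)O[C@H]2[C@@H]1O`, turns the 3,4-dichlorophenyl into 4-chlorophenyl: hydrogen in place of chloro on an aromatic carbon. Among the measured compounds shown here, only one measured step touches a substituent on this aromatic ring, and it stayed small: a 1.8-fold higher number from compound 1 to compound 2 (0.26 log units; within the scatter). For the measured compounds named here, that step puts methyl, not hydrogen, in place of chloro, so it is only a loose guide, and no measured pair shows a chloro group simply being removed. Compound 4 also shares the 4-chlorophenyl with compound 1, yet differs from it elsewhere, so that lower number cannot be carried over. No step beyond the scatter is therefore expected in this assay, and the estimated change is a 1.1-fold lower number from compound 3 to compound 4 (0.03 log units; within the scatter). For compound 4 the estimate is 28 ug/mL, with an expected range from 12 ug/mL to 65 ug/mL.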

Compound 4, half-maximal cytotoxic concentration: 35.5 ug/mL
Estimate against measurement, compound 4: 1.3-fold (0.10 log units) below; the range from low to high includes it.
By their numbers in this assay, from the lowest: compounds 1 and 2 (each within the scatter of the next); then compounds 3 and 4 (each within the scatter of the next).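

In this assay, the step for taking one chloro group off the 3,4-dichlorophenyl is a 1.2-fold higher number from compound 3 to compound 4 (0.07 log units; within the scatter), so on this aromatic carbon, ortho to a chloro group, hydrogen and chloro cannot be told apart by this read-out. The earlier step put methyl in place of chloro on a different carbon of the ring and could not show this. With the 4-chlorophenyl kept the same, the change that does stand out is hydrogen in place of benzyl on the oxygen, a step of an 8.4-fold higher number from compound 1 to compound 4 (0.92 log units; beyond the scatter), and no outside measurement is available to explain either result.

From the compounds shown here alone, whether a different kind of group on the same aromatic carbon, such as an amine, a carboxylic acid or a methoxy group, would also leave the number unchanged remains open, as does the effect of removing the remaining chloro group to give a plain phenyl. Going by these compounds, it is also open how the number would respond to a small methyl group or a longer chain on the oxygen that carries hydrogen in compound 4 and benzyl in compound 1.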